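Trifluoromethyl in Place of Phenyl on the Fused Ring

The compounds below may be only part of what the source reports. "The series", "measured", "known", "first", "only" and "open" are said of these compounds alone.

Of the compounds shown here, two have so far been measured in an assay on isolated protein for inhibition of alpha-ketoglutarate-dependent dioxygenase alkB homolog 3 (Homo sapiens), read by polymerase chain reaction, with a stated time of 1 h; a higher number here means a weaker inhibitor, a lower number a stronger inhibitor. Going by the values given here, compound 1 `Cc1[nH]n(-c2nc3cc(-c4ccccc4)ccc3[nH]2)c(=O)c1Cc1ccccc1` is the only one with an actual number: in this assay compound 1 gives 810 nM. Compound 2 `Cc1[nH]n(-c2nc3ccccc3s2)c(=O)c1C` returns only a limit of this assay, not a number; in this assay compound 2 gives > 10000 nM. That result is the limit of > 10000 nM in this assay, at which 1 of the 2 values shown sits. Compound 1 therefore stands alone as the reference point, with nothing against which to rank it.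

Compound 3 `Cc1[nH]n(-c2nc3cc(C(F)(F)F)ccc3[nH]2)c(=O)c1Cc1ccccc1` is the next compound to be measured in this assay. Compound 3 differs from compound 1 in a single place: trifluoromethyl in place of phenyl on an aromatic carbon. Among the compounds with values here, no pair of measured compounds differs in one place, so there is no measured step from which the size of this change can be read. With the loss of a whole aromatic ring, a moderate weakening is expected rather than a change within the scatter, a step of a 3.7-fold higher number from compound 1 to compound 3 (0.57 log units; beyond the scatter). For compound 3 the estimate in this assay is 3000 nM, with a likely range from 900 nM to 10000 nM.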

Compound 3, half-maximal inhibitory concentration: 610 nM
For compound 3 the middle estimate is 4.9-fold (0.69 log units) above the measured one; the measured number lies below the stated range.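

In this assay the exchange of phenyl for trifluoromethyl on this aromatic carbon gives a 1.3-fold lower number from compound 1 to compound 3 (0.12 log units; within the scatter) and so leaves the two compounds indistinguishable. Going by these compounds alone, this is the first step between measured compounds that differ in one place, and it shows that, for this pair, the six-membered aromatic ring carried by compound 1 at this position is not required for a value of this size: trifluoromethyl, with no ring and fewer heavy atoms, reads alike in this assay. Nothing given so far accounts for why these two groups read alike.

The compounds shown leave open whether the group at this position matters at all, as only phenyl and trifluoromethyl have been read there, and a bare hydrogen, a methyl, a chlorine, an amine or a carboxylic acid on the same aromatic carbon would test this directly. They also leave open whether this tolerance holds for a longer chain at the same place, or when the rest of the core of compound 3 is changed.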